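The source may hold more compounds than are shown below. What is called first, only, known or untested is meant among the compounds shown, and "the series" means these compounds.

Measured compounds:
Compound 1 `COc1cc2ncnc(Nc3ccc(Cl)c(C(F)(F)F)c3)c2cc1OCCCCC(=O)Nc1ccc(S(N)(=O)=O)cc1`, 3910 nM
Compound 2 `COc1cc2ncnc(Nc3ccc(F)c(Br)c3)c2cc1OCCCCC(=O)Nc1ccc(S(N)(=O)=O)cc1`, 8020 nM
Compound 3 `NS(=O)(=O)c1ccc(NC(=S)Nc2ccc3ncnc(Nc4ccc(Cl)c(C(F)(F)F)c4)c3c2)cc1`, 18200 nM

In a functional assay on A-431 cells (Homo sapiens) for antiproliferative activity, read by MTT assay, with a stated time of 72 h (a higher number here means a weaker inhibitor, a lower number a stronger inhibitor), compound 1 gives 3910 nM and compound 2 gives 8020 nM. The two share a core and differ in one place: 3-bromo-4-fluorophenyl in place of 4-chloro-3-(trifluoromethyl)phenyl on a nitrogen on an aromatic ring. That change produced a 2.1-fold higher number from compound 1 to compound 2 (0.31 log units; beyond the scatter).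

Compound 3, in this assay, gives 18200 nM, the highest of the three numbers. Compound 3 and compound 1 carry the same aryl group on the nitrogen on the aromatic ring, but their cores differ; the difference between the two cores is not broken down here.

Compound 4 `NS(=O)(=O)c1ccc(NC(=S)Nc2ccc3ncnc(Nc4ccc(F)c(Br)c4)c3c2)cc1` has not yet been measured. It stands to compound 3 as compound 2 stands to compound 1, by the same kind of change: 3-bromo-4-fluorophenyl in place of 4-chloro-3-(trifluoromethyl)phenyl on a nitrogen on an aromatic ring. The place is described in the same words in both pairs. For the measured compounds named here, only one earlier instance of this change exists, on the core of compound 1, so the expectation rests on that single step a 2.1-fold higher number from compound 1 to compound 2 (0.31 log units; beyond the scatter) and on the assumption that the change behaves alike on the core of compound 3. The step from compound 3 to compound 4 is therefore expected to be a 2.0-fold higher number from compound 3 to compound 4 (0.30 log units; within the scatter), a modest rise, of about the same size as the earlier one.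

Compound 4 is estimated at 36000 nM in this assay, with a range from 15000 nM to 90000 nM. Because compound 3 already gives 18200 nM, a high starting point, compound 4 is expected to be a weaker inhibitor still.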

Compound 4, half-maximal inhibitory concentration: 18200 nM
Estimate against measurement, compound 4: 2.0-fold (0.30 log units) above, within the range that was stated.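

In this assay, the exchange of 4-chloro-3-(trifluoromethyl)phenyl for 3-bromo-4-fluorophenyl on a nitrogen on an aromatic ring gives no change at the digits printed from compound 3 to compound 4 (within the scatter), so the modest rise seen on the core of compound 1 does not appear at the digits printed on the core of compound 3. Set side by side, the two steps cannot be told apart: the same change on two cores in this assay, a 2.1-fold higher number (0.31 log units; beyond the scatter) from compound 1 to compound 2 and no change at the digits printed (within the scatter) from compound 3 to compound 4, 2.1-fold (0.31 log units) apart, within the scatter of two such steps. This shows that, for these two pairs, the effect of the change on one core is compatible with its effect on the other and that neither step is large, but it does not show that the two effects are identical, and with one pair per core it gives no rule for any further core.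

The compounds shown leave open whether the same exchange stays as small when a carboxylic acid stands in place of the terminal sulfonamide, or when a morpholine is carried on the chain of compound 1. They also leave open how a 3-ethynylphenyl group on the same nitrogen would compare with the two aryl groups exchanged here, on either core.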